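Methyl Additions on Two Amide Tails of a Shared Core

This account rests on a few compounds, and the source may have more. Where it says the series, first, only, none or still open, it means among the compounds named here.

Compound 1 `Cn1c(-c2ccc(NC(=O)CSc3nc4ccccc4o3)cc2)nc(-c2ccccc2)c1-c1ccccc1` and compound 3 `Cn1c(-c2ccc(NC(=O)CN3CCN(Cc4ccccc4)CC3)cc2)nc(-c2ccccc2)c1-c1ccccc1` share the same core but carry different amide tails; the difference between the two cores is not broken down here. In a functional assay on MCF7 cells (Homo sapiens) for cytotoxicity, read by MTT assay, with a stated time of 24 h (on this read-out lower numbers stand for stronger inhibition and higher numbers for weaker inhibition), compound 1 gives 11.2 ug/mL, while compound 3 gives 80 ug/mL. Compound 2 `Cc1ccc2oc(SCC(=O)Nc3ccc(-c4nc(-c5ccccc5)c(-c5ccccc5)n4C)cc3)nc2c1` arises from compound 1 by methyl in place of hydrogen on an aromatic carbon, and in this assay compound 2 gives 22.4 ug/mL. That change produced a 2.0-fold higher number from compound 1 to compound 2 (0.30 log units; within the scatter).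

Compound 4 `Cc1ccc(CN2CCN(CC(=O)Nc3ccc(-c4nc(-c5ccccc5)c(-c5ccccc5)n4C)cc3)CC2)cc1` arises from compound 3 by methyl in place of hydrogen on an aromatic carbon. This is the same kind of change, but its surroundings differ: in compound 2 the methyl sits on a six-membered aromatic ring of carbon only, part of a fused or bridged system of two rings, meta to a fused ring and para to a fused ring, whereas in compound 4 it sits on a six-membered aromatic ring of carbon only, para to a large group.

For compound 4 the expected step in this assay is a 1.5-fold higher number from compound 3 to compound 4 (0.18 log units; within the scatter), resting on the earlier step of a 2.0-fold higher number from compound 1 to compound 2 (0.30 log units; within the scatter) having stayed within the scatter. For compound 4 the estimate in this assay is 120 ug/mL, between 50 ug/mL and 280 ug/mL.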

Compound 4, half-maximal inhibitory concentration: 80 ug/mL
For compound 4 the middle estimate is 1.5-fold (0.18 log units) above the measured one; measured number inside the range.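

In this assay, turning the benzyl group of compound 3 into a 4-methylbenzyl group gave no change at the digits printed from compound 3 to compound 4 (within the scatter). This suggests that, on these two amide tails, adding a methyl to an aromatic carbon leaves the number within the usual spread of repeat measurements, but it does not prove that the methyl has no effect, since a small real effect could hide inside that spread, and two pairs of compounds cannot establish a rule for the whole series. Set side by side, the two steps give no sign that the change behaves differently from one tail to the other: the same change on two cores in this assay, a 2.0-fold higher number (0.30 log units; within the scatter) from compound 1 to compound 2 and no change at the digits printed (within the scatter) from compound 3 to compound 4, 2.0-fold (0.30 log units) apart, within the scatter of two such steps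

The compounds shown leave open whether a different group at these aromatic carbons, such as a chlorine atom, a methoxy group or an amine, would shift the number beyond the scatter. They also leave open whether a longer chain in place of the methyl, such as an ethyl or propyl group, would behave alike on both tails.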